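Removing the ring methyl from compound 3's amine nitrogen

A few compounds are considered here, and "the series" means these few. Any claim that something is new, unique, unknown or untested is made for them only; others in the source may bear on it.

For the measured compounds named here, compound 3 `COc1cc2c(CN3CCN(C)CC3)coc2cc1C` is one of three compounds measured in a functional assay on HEK293 cells for agonist activity at melatonin receptor type 1A (Homo sapiens), read by calcium flux (on this read-out higher numbers stand for an effect only at larger amounts of compound and lower numbers for an effect already at smaller amounts), where compound 3 gives 330000 nM. Going by the values given here, compound 1 `COc1cc2c(CO)coc2cc1C` gives 700000 nM and compound 2 `COc1cc2c(CN)coc2cc1C` gives 250000 nM; the only step between single-point neighbours, a 2.8-fold lower number from compound 1 to compound 2 (0.45 log units; beyond the scatter), involves a change unrelated to the amine ring. Compound 4 `COc1cc2c(CN3CCNCC3)coc2cc1C` differs from compound 3 by hydrogen in place of methyl on an amine nitrogen in a ring. Among the compounds with values here, no measured step touches this ring nitrogen, so the data give no guide to the size of the change. On that basis the step from compound 3 to compound 4 is expected to be a 1.1-fold lower number from compound 3 to compound 4 (0.04 log units; within the scatter), with no change beyond the usual scatter. Compound 4 is therefore estimated at 300000 nM, within a range from 100000 nM to 900000 nM.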

Compound 4, half-maximal effective concentration: 460000 nM
Estimate against measurement, compound 4: 1.5-fold (0.19 log units) below; low and high end bracket the measured number.
By their numbers in this assay, from the lowest: compounds 2, 3, 4 and 1 (each within the scatter of the next, the first and the last beyond it).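

In this assay, for the compounds shown here, the first measured step on this ring nitrogen, a 1.4-fold higher number from compound 3 to compound 4 (0.14 log units; within the scatter), shows that hydrogen in place of methyl gives no change beyond the scatter. Piperazin-1-yl likewise stays within the scatter of the amino group in a 1.8-fold higher number from compound 2 to compound 4 (0.26 log units; within the scatter) and of the hydroxy group in a 1.5-fold lower number from compound 1 to compound 4 (0.18 log units; within the scatter). The compounds shown leave open whether a larger group on this nitrogen, such as ethyl or acetyl, or a morpholine ring in place of the piperazine would move the number beyond the scatter. No supporting data bear on this result.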